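Trifluoromethoxy to trifluoromethyl: from compound 3 to compound 4

This account rests on a few compounds, and the source may have more. Where it says the series, first, only, none or still open, it means among the compounds named here.

Measured in a functional assay on RAW264.7 cells (Mus musculus) for inhibition, read by polymerase chain reaction, with stated times of 12 h and 6 h; on this read-out higher numbers stand for weaker inhibition and lower numbers for stronger inhibition:
compound 1 `Cc1ccc(CN2CCC(NC(=O)C(C)(C)Oc3ccc(C(=O)c4ccc(Cl)cc4)cc3)CC2)cc1`: 8560 nM
compound 2 `COc1ccc(CN2CCC(NC(=O)C(C)(C)Oc3ccc(C(=O)c4ccc(Cl)cc4)cc3)CC2)cc1`: 4570 nM
compound 3 `CC(C)(Oc1ccc(C(=O)c2ccc(Cl)cc2)cc1)C(=O)NC1CCN(Cc2ccc(OC(F)(F)F)cc2)CC1`: 9760 nM

Among these three, compound 3 is not separated from one neighbour, a 1.1-fold higher number from compound 1 to compound 3 (0.06 log units; within the scatter), and lies a modest distance from the other, a 2.1-fold higher number from compound 2 to compound 3 (0.33 log units; beyond the scatter). The next compound, compound 4 `CC(C)(Oc1ccc(C(=O)c2ccc(Cl)cc2)cc1)C(=O)NC1CCN(Cc2ccc(C(F)(F)F)cc2)CC1`, has not been measured. It keeps the shared core and changes a single group, with trifluoromethyl in place of trifluoromethoxy on an aromatic carbon, para to a large group (trifluoromethyl in place of trifluoromethoxy on an aromatic carbon).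

Among the measured compounds shown here, this exact swap has no measured precedent, so the guide is the set of changes already seen on that same aromatic carbon. Methoxy in place of methyl gave a 1.9-fold lower number from compound 1 to compound 2 (0.27 log units; within the scatter), and trifluoromethoxy in place of methyl gave a 1.1-fold higher number from compound 1 to compound 3 (0.06 log units; within the scatter). The largest of the three steps there is the modest one quoted above. On that evidence, no step beyond the scatter is expected in this assay, and the data favour no direction. The estimated change is a 1.2-fold lower number from compound 3 to compound 4 (0.09 log units; within the scatter). Compound 4 is expected at about 8000 nM, with an estimated range of 3800 nM to 16000 nM.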

Compound 4, half-maximal inhibitory concentration: 4400 nM
Compound 4: middle estimate off by 1.8-fold (0.26 log units), on the high side, within the range that was stated.
By their numbers in this assay, from the lowest: compounds 4, 2, 1 and 3 (each within the scatter of the next, the first and the last beyond it).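

In this assay, trifluoromethyl and trifluoromethoxy on this aromatic carbon turn out to be distinguishable, a 2.2-fold lower number from compound 3 to compound 4 (0.35 log units; beyond the scatter), so the two fluorinated groups, which differ by a single oxygen, cannot be treated as interchangeable here. Trifluoromethyl does not separate from methoxy, a 1.0-fold lower number from compound 2 to compound 4 (0.02 log units; within the scatter), nor from methyl, a 1.9-fold lower number from compound 1 to compound 4 (0.29 log units; within the scatter), which leaves compound 1 within the scatter of all three other compounds and compound 3 beyond it only against compound 2 and compound 4. Among the compounds shown here, the position therefore tolerates these four groups within a narrow band, with only the step away from trifluoromethoxy to either methoxy or trifluoromethyl reaching a modest size, and nothing available explains this difference.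

For the compounds shown here, all four compounds vary only this one group on the same carbon, so it remains open whether a nitrile, an amine or a carboxylic acid there would leave that narrow band. On these data alone, it also remains open whether the step from trifluoromethoxy to trifluoromethyl would recur with the group on another carbon of the ring or with a different core.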